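A Furan Swap at the Weak End of the Series

This account rests on a few compounds, and the source may have more. Where it says the series, first, only, none or still open, it means among the compounds named here.

Compound 3 `O=C1NC(=O)/C(=C\c2ccc(OCC(=O)N3N=C(c4ccc(F)cc4)CC3c3ccccc3Cl)cc2)S1` was tested in an assay on cells for inhibition of histone deacetylase 8 (Homo sapiens), read by fluorescence, with a stated time of 30 min; a lower number here means a stronger inhibitor, a higher number a weaker inhibitor. In this assay compound 3 gives > 50000 nM, which is a limit of the assay and not a number. Within the data shown here, two measured steps bear on the coming change. Compound 1 `O=C1NC(=O)/C(=C\c2ccc(OCC(=O)N3N=C(c4ccccc4)CC3c3ccccc3Cl)cc2)S1` gives 29000 nM in this assay. The step of an at least 1.7-fold higher number from compound 1 to compound 3 (0.23 log units; that floor lies within the scatter) shows that fluoro in place of hydrogen on an aromatic carbon brought no stronger inhibition. Compound 2 `O=C1NC(=O)/C(=C\c2ccc(OCC(=O)N3N=C(c4ccc(F)cc4)CC3c3ccccc3)cc2)S1` gives > 50000 nM in this assay, again a limit of the assay rather than a number. The step that the two limits leave unreadable from compound 2 to compound 3 cannot be sized because the limit of > 50000 nM in this assay, at which 2 of the 3 values shown sit, holds both of its ends. Compound 4 `O=C1NC(=O)/C(=C\c2ccc(OCC(=O)N3N=C(c4ccc(F)cc4)CC3c3ccco3)cc2)S1` is not yet measured; it differs from compound 3 by furan-2-yl in place of 2-chlorophenyl on a saturated ring carbon. Among the measured compounds shown here, no measured step touches this part of the molecule, and every value shown sits far toward weak inhibition, so compound 4 is expected to stay in the same region. The expected step of a number no higher from compound 3 to compound 4 (the limit leaves the size open) is estimated to be none beyond the scatter. For compound 4 the estimated value in this assay is 50000 nM, expected to fall between 15000 nM and 150000 nM, with a real chance that only a limit is again reported.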

Compound 4, half-maximal inhibitory concentration: > 50000 nM
Compound 4 ended at the assay's limit; the forecaster's own chance of this, stated with the estimate: 60%; the middle value lies on the limit itself.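

Compound 4 also stops at a limit of the assay rather than a number, so neither of its steps, from compound 2 or from compound 3, can be read in this assay: the limit of > 50000 nM in this assay, at which 3 of the 4 values shown sit. As far as these compounds go, whether furan-2-yl differs at all from phenyl or 2-chlorophenyl on that saturated ring carbon remains open.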